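Aryl swap on the triazole nitrogen: ethoxy to dimethyl

The source may hold more compounds than are shown below. What is called first, only, known or untested is meant among the compounds shown, and "the series" means these compounds.

Compound 1 `N#CC1=C(N)Oc2c(c3nc4ccccc4nc3c3ccccc23)C12C(=O)N(Cc1cnnn1-c1cccc(Br)c1)c1ccccc12`: in a functional assay on A549 cells (Homo sapiens) for antiproliferative activity, read by MTT assay, with a stated time of 48 h (a higher number here means a weaker inhibitor, a lower number a stronger inhibitor), compound 1 gives > 50000 nM, which is a limit of the assay.
Compound 2 `CCOc1ccc(-n2nncc2CN2C(=O)C3(C(C#N)=C(N)Oc4c3c3nc5ccccc5nc3c3ccccc43)c3ccccc32)cc1`: in this assay compound 2 gives 25200 nM.

Compound 2 holds the only measured number in this assay; the other value is a limit, as shown by the limit of > 50000 nM in this assay, at which 1 of the 2 values shown sits. Going by the values given here, the one measured step, an at least 1.9-fold lower number from compound 1 to compound 2 (0.29 log units; that floor lies within the scatter), also changes the aryl group on the same aromatic nitrogen, and its floor lies within the scatter, so it says little about the size of such changes.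

Compound 3 `Cc1ccc(-n2nncc2CN2C(=O)C3(C(C#N)=C(N)Oc4c3c3nc5ccccc5nc3c3ccccc43)c3ccccc32)cc1C` differs from compound 2 by 3,4-dimethylphenyl in place of 4-ethoxyphenyl on an aromatic nitrogen. Among the compounds with values here, since the only comparable step, an at least 1.9-fold lower number from compound 1 to compound 2 (0.29 log units; that floor lies within the scatter), is not resolved beyond the scatter, no step beyond the scatter is expected in this assay, and the expected step is a 1.0-fold lower number from compound 2 to compound 3 (0.00 log units; within the scatter). Compound 3 is therefore estimated at 25000 nM, between 8000 nM and 80000 nM.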

Compound 3, half-maximal inhibitory concentration: > 50000 nM
Compound 3: a limit, no number (the forecaster's own chance of this, stated with the estimate: 30%); middle value at least 2.0-fold (0.30 log units) away from the limit.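

Across the three aryl groups now shown on this nitrogen, 3-bromophenyl and 3,4-dimethylphenyl both end at a limit rather than a number in this assay: the limit of > 50000 nM in this assay, at which 2 of the 3 values shown sit.

Replacing 4-ethoxyphenyl with 3,4-dimethylphenyl, which removes the one oxygen of the leaving group, gives an at least 1.9-fold higher number from compound 2 to compound 3 (0.29 log units; that floor lies within the scatter), so this change, like the earlier one, is not resolved beyond the scatter. Compound 1 and compound 3 both stand as limits, so the step between them cannot be read.

The compounds shown leave open whether any aryl group at this position can give a number clearly separated from that of compound 2. An amine or a carboxylic acid on the phenyl ring, or a longer alkoxy chain in place of ethoxy, would test this in this assay.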